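Carbonate ester prodrugs of a shared core

This account rests on a few compounds, and the source may have more. Where it says the series, first, only, none or still open, it means among the compounds named here.

Measured so far:
compound 1, `CCOC(=O)OCOC(=O)C1=C(S[C@@H]2CN[C@H](C(=O)Nc3cccc(C(=O)O)c3)C2)[C@H](C)[C@@H]2[C@@H]([C@@H](C)O)C(=O)N12`, gives 0% in an ADME assay on a cell-free system (plasma, Rattus norvegicus) for metabolic stability, read by LC-MS, with a stated time of 60 min, at 37 degrees C, tested at 50 uM; a lower number here means that less of the compound is left, a higher number that more of the compound is left
compound 2, `CCOC(=O)C1=C(S[C@@H]2CN[C@H](C(=O)Nc3cccc(C(=O)O)c3)C2)[C@H](C)[C@@H]2[C@@H]([C@@H](C)O)C(=O)N12`, gives "not determined" (no result reported) in this assay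

Compound 2 stands at "not determined" (no result reported) in this assay, so the only measured point in the series is compound 1 at 0%. Compound 3, `CC(C)OC(=O)OCOC(=O)C1=C(S[C@@H]2CN[C@H](C(=O)Nc3cccc(C(=O)O)c3)C2)[C@H](C)[C@@H]2[C@@H]([C@@H](C)O)C(=O)N12`, differs from compound 2 by (isopropoxycarbonyl)oxy in place of methyl on a saturated chain carbon bound to an oxygen next to a carbonyl group. No measured pair sizes this step, so no direction beyond the scatter can be read from compound 2 itself. Compound 3 is expected to sit close to compound 1, whose carbonate is already fully consumed at 0%. Compound 3 is therefore estimated at 2%, with a range from 0% to 15%.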

Compound 3, percent of the compound remaining in the plasma assay: 0%
The estimate for compound 3 lay 2 percentage points above the measured number; low and high end bracket the measured number.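

Going by these compounds alone, in the plasma assay the added methyl on a saturated chain carbon bound to an oxygen next to a carbonyl group and a saturated chain carbon gives no change at the digits printed from compound 1 to compound 3 (within the scatter), and no compound is left in either case. In a physicochemical assay for metabolic stability, read by LC-MS, in phosphate buffer, with a stated time of 3 h, at pH 7.4, tested at 50 uM (a higher number here means that more of the compound is left, a lower number that less of the compound is left), compound 2 gives > 95%, which is a limit of the assay. In the physicochemical assay compound 3 gives > 95%, likewise a limit, and no step to compound 2 can be read: the limit of > 95% in the physicochemical assay, at which 2 of the 2 values shown sit.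

Going by these compounds, it remains open whether a longer chain or an amine in the carbonate would leave any compound in the plasma assay. On these data alone, how quickly compound 1 and compound 3 are consumed within the stated time also stays open.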